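The source may report more compounds than this note shows. Statements on the series, on what has been measured and on what is new or still open speak of the compounds shown alone.

Two compounds share one core and differ only in the group that ends a two-carbon chain on that core. Compound 1 `Cc1ccccc1-c1nc(C(=O)Nc2cccc(C(=O)O)c2)c(CCC2CCCCC2)[nH]1` carries a cyclohexyl there, and in a functional assay on stomach for antagonist activity at Gastrin/cholecystokinin type B receptor (Rattus norvegicus) (on this read-out higher numbers stand for weaker binding and lower numbers for tighter binding), compound 1 gives 20 nM. Compound 2 `Cc1ccccc1-c1nc(C(=O)Nc2cccc(C(=O)O)c2)c(CCc2ccccc2)[nH]1` carries a phenyl instead, and in this assay compound 2 gives 1170 nM. Among the compounds with values here, the single measured step, a 59-fold higher number from compound 1 to compound 2 (1.77 log units; beyond the scatter), shows that swapping the saturated six-membered ring for the flat aromatic one costs a great deal. Within the data shown here, on the two numbers known, compound 2 stands at the higher, weaker end, with compound 1 the only neighbour.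

Compound 3 `Cc1ccccc1-c1nc(C(=O)Nc2cccc(C(=O)O)c2)c(CCC(C)C)[nH]1` is the next step from compound 2: isopropyl in place of phenyl on a saturated chain carbon, two bonds along the chain from an aromatic carbon. Among the measured compounds shown here, the one step that bears on this is the cyclohexyl-to-phenyl change between compounds 1 and 2, which was large, and it suggests that leaving the aromatic ring for a saturated group should move the number back down. Isopropyl is smaller than cyclohexyl, so a full return is not assumed. The expectation for compound 3 in this assay is therefore 150 nM, within a range of 40 nM to 600 nM, an expected step of a 7.8-fold lower number from compound 2 to compound 3 (0.89 log units; beyond the scatter).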

Compound 3, dissociation constant: 26.3 nM
Compound 3: the middle estimate sits 5.7-fold (0.76 log units) above what was measured; the whole stated range lies above it.
By their numbers in this assay, from the lowest: compounds 1 and 3 (each within the scatter of the next); then compound 2.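

In this assay, a 44-fold lower number from compound 2 to compound 3 (1.65 log units; beyond the scatter), so at the end of this chain a ring is not needed for a low number: isopropyl, which has no ring at all, serves there. Set against the cyclohexyl compound, the picture sharpens, since a 1.3-fold higher number from compound 1 to compound 3 (0.12 log units; within the scatter), which means compound 1 and compound 3 cannot be told apart even though isopropyl is the smaller group. Among these three compounds, then, the phenyl of compound 2 is the one end group that stands apart, rather than the two saturated groups forming a ladder of size, yet nothing measured here explains why this is so.

Open still is how far the saturated end group can shrink or grow before the number moves, for instance with a methyl, a tert-butyl or a longer chain such as n-hexyl. Also open, on these data alone, is whether the penalty belongs to aromatic rings in general, which a pyridine ring in place of the phenyl would test, and how an end group carrying an amine or a hydroxyl would fare at the same position.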